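Hydroxy to Fluoro in a Dopamine Receptor Agonist Series

A few compounds are considered here, and "the series" means these few. Any claim that something is new, unique, unknown or untested is made for them only; others in the source may bear on it.

Of the compounds shown here, three sharing one core have been measured in a functional assay on HEK293 cells for agonist activity at D(4) dopamine receptor (Homo sapiens), read by FLIPR; a higher number here means a larger maximal response, a lower number a smaller maximal response. Compound 1 `Cc1cc(C)cc(NC(=O)CN2CCC(c3cccc[n+]3[O-])CC2)c1` gives 76%, compound 2 `Cc1cccc(NC(=O)CN2CCC(c3cccc(O)c3)CC2)c1` gives 66%, and compound 3 `O=C(NCN1CCC(c2cccc[n+]2[O-])CC1)c1cc(Cl)cc(Cl)c1` gives 64%. On these numbers compound 2 sits between the other two, yet its distance to compound 3 and its distance to compound 1 both fall within the usual scatter of repeated measurements, so the three maximal responses cannot be told apart with confidence.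

The step under consideration leads from compound 2 to compound 4 `Cc1cccc(NC(=O)CN2CCC(c3cccc(F)c3)CC2)c1`, which has not yet been measured in this assay. The difference between the two structures is fluoro in place of hydroxy on an aromatic carbon. Among the compounds with values here, no measured pair in this set shows the same change, so its effect on the maximal response is not known from the data at hand.

Given that the three measured compounds, despite different substituents, all reach a similar maximal response, the step from compound 2 to compound 4 is expected to stay within the scatter, estimated as a number 4 percentage points lower from compound 2 to compound 4 (within the scatter). Compound 4 is therefore expected to give about 62% in this assay, with a range from 45% to 80%.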

Compound 4, largest response reached (reported as efficacy), in percent of the reference or control that the assay uses: 40%
Beside the measured number, compound 4's estimate is 22 percentage points above it; the measured number lies below the stated range.
By their numbers in this assay, from the lowest: compound 4; then compounds 3, 2 and 1 (each within the scatter of the next, the first and the last beyond it).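

In this assay, within the data shown here, the exchange of 3-hydroxyphenyl for 3-fluorophenyl, on an aromatic carbon meta to a large group, gives a number 26 percentage points lower from compound 2 to compound 4 (beyond the scatter) and is the first single change in this set that can be read on its own. Among these compounds, it shows that the maximal response at this position can depend on one heavy atom, something the earlier compounds could not show, since they differ from one another in more than one place. The counts of the two groups also differ: hydroxy has 1 hydrogen-bond donor and 1 hydrogen-bond acceptor, fluoro 0 of each, but nothing at hand connects this difference or any other to the lower response, and no evidence bears on what lies behind the step.

On these data alone, what stays open is whether the step reflects the departure of hydroxy or the arrival of fluoro, a question that a plain hydrogen, a methoxy group or an amine at the same place could help to separate. A single pair also leaves open whether the same exchange would have a similar effect on the maximal response in compounds with a different amide portion.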